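The compounds below may be only part of what the source reports. "The series", "measured", "known", "first", "only" and "open" are said of these compounds alone.

Measured in an assay on CHO cells with metabotropic glutamate receptor 5 (Homo sapiens) as the target; on this read-out higher numbers stand for an effect only at larger amounts of compound and lower numbers for an effect already at smaller amounts:
compound 1 `O=C(Nc1cc(-c2ccccc2)nn1-c1ccccc1)c1ccccc1` gives 40 nM
compound 2 `O=C(Nc1cc(-c2ccccc2)nn1-c1ccccc1)c1ccccn1` gives 290 nM

Among the compounds with values here, compound 2 stands at the higher of these two numbers; the only measured step, a 7.3-fold higher number from compound 1 to compound 2 (0.86 log units; beyond the scatter), separates it from compound 1. Compound 3 `O=C(Nc1cc(-c2ccccc2)nn1-c1ccccc1)c1ccccc1F` differs from compound 2 by 2-fluorophenyl in place of pyridin-2-yl on a carbonyl carbon. Within the data shown here, this change largely undoes the one step on record, since it returns a carbon-only ring to the carbonyl carbon, so a step of similar size in the opposite direction is expected, a 5.8-fold lower number from compound 2 to compound 3 (0.76 log units; beyond the scatter), a lower number in this assay. Compound 3 is therefore expected near 50 nM, within a range from 15 nM to 160 nM.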

Compound 3, half-maximal effective concentration: 75 nM
Estimate against measurement, compound 3: 1.5-fold (0.18 log units) below; the range from low to high includes it.
By their numbers in this assay, from the lowest: compounds 1 and 3 (each within the scatter of the next); then compound 2.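

Putting 2-fluorophenyl in place of pyridin-2-yl gives a 3.9-fold lower number from compound 2 to compound 3 (0.59 log units; beyond the scatter) and so shows that compound 2 stays apart from a second compound with a carbon-only ring on the carbonyl carbon. Fluoro in place of hydrogen on an aromatic carbon gives a 1.9-fold higher number from compound 1 to compound 3 (0.27 log units; within the scatter) and so cannot be told from repeat scatter. Nothing measured here explains either step.

From the compounds shown here alone, what remains open is whether the pyridine nitrogen or something else sets compound 2 apart. Also open, going by these compounds, is how a methoxy group, a chlorine or an amine on this ring would compare with fluoro.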